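Methyl for Chloro on a Kynurenine Monooxygenase Inhibitor Series

The compounds below may be only part of what the source reports. "The series", "measured", "known", "first", "only" and "open" are said of these compounds alone.

Compound 2 `COC(=O)C(=O)/C=C(\O)c1ccc(Cl)c(Cl)c1` stands level with compound 1 `COC(=O)C(=O)/C=C(\O)c1cccc(Cl)c1` in an assay for inhibition of kynurenine 3-monooxygenase (Rattus norvegicus); on this read-out higher numbers stand for weaker inhibition and lower numbers for stronger inhibition: compound 2 gives 1900 nM and compound 1 gives 1900 nM, with no change at the digits printed from compound 1 to compound 2 (within the scatter) between them. Compound 3 `COC(=O)C(=O)/C=C(\O)c1ccc(F)c(Cl)c1` gives 2600 nM, and both a 1.4-fold higher number from compound 2 to compound 3 (0.14 log units; within the scatter) and a 1.4-fold higher number from compound 1 to compound 3 (0.14 log units; within the scatter) remain within the scatter. Compound 4 `COC(=O)C(=O)/C=C(\O)c1ccc(Cl)c(C)c1` differs from compound 2 by methyl in place of chloro on an aromatic carbon. The three measured steps all alter substituents on the same aromatic ring and none moves this assay beyond the scatter, so a similarly small effect is expected here; the estimated change is no change at the digits printed from compound 2 to compound 4 (within the scatter). Compound 4 is therefore expected to give about 1900 nM, within a range from 1000 nM to 4000 nM.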

Compound 4, half-maximal inhibitory concentration: 4900 nM
Compound 4: middle estimate off by 2.6-fold (0.41 log units), on the low side; measured number outside the range, above it.
By their numbers in this assay, from the lowest: compounds 1, 2, 3 and 4 (each within the scatter of the next, the first and the last beyond it).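

In this assay, within the data shown here, the replacement of this chloro by methyl gives a 2.6-fold higher number from compound 2 to compound 4 (0.41 log units; beyond the scatter), the only step in the set beyond the scatter. Among these compounds, the three earlier steps all left this chloro in place and changed another aromatic carbon, so this is the first sign that the series responds to a change at this position. Nothing shown accounts for the shift. 

The compounds shown leave open how a methoxy group, an amine or a trifluoromethyl group would read at this carbon. As far as these compounds go, whether the same replacement would give a similar step with fluoro or hydrogen in place of the remaining chloro also stays open.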